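Swapping an Indole for a Fluorophenyl Group

The source may hold more compounds than are shown below. What is called first, only, known or untested is meant among the compounds shown, and "the series" means these compounds.

This small series shares a pyridone core carrying a methylamide, with differing groups hung on the ring nitrogen through a single saturated carbon. Compound 1 `CNC(=O)c1cc(C(=O)NC2CC2)cn(CC2CCOCC2)c1=O` bears an oxan-4-yl group there and in a physicochemical assay for lipophilicity, at pH 7.4 (on this read-out lower numbers stand for lower lipophilicity and higher numbers for higher lipophilicity), gives 1.5. Compound 2 `CNC(=O)c1cc(C(=O)NC2CC2)cn(Cc2cccc3[nH]ccc23)c1=O` carries a 1H-indol-4-yl group instead and in this assay gives 2.9, the highest of the three numbers shown. Compound 3 `CNC(=O)c1ccc(=O)n(Cc2ccccc2)c1` has a simpler core without the cyclopropyl amide and a plain benzyl group; in this assay compound 3 gives 1.6.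

The step from compound 2 to compound 4 `CNC(=O)c1cc(C(=O)NC2CC2)cn(Cc2cccc(F)c2)c1=O` makes this change: 3-fluorophenyl in place of 1H-indol-4-yl on a saturated chain carbon bound to an aromatic nitrogen. Compound 4 is not yet measured.

Going by the values given here, only one measured step touches the same place, a number 1.40 log units higher from compound 1 to compound 2 (beyond the scatter), and it shows how strongly this position can move the read-out. Among the compounds with values here, compound 3 also points the way: its value sits well under that of compound 2, though it differs in two places, so no clean step can be drawn. An aromatic ring remains in compound 4, so a modest change is expected; compound 4 is estimated at 2.7, between 2.2 and 3.2, a step of a number 0.20 log units lower from compound 2 to compound 4 (within the scatter).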

Compound 4, distribution coefficient: 3.2
Estimate against measurement, compound 4: 0.50 log units below; measured number inside the range.
By their numbers in this assay, from the lowest: compounds 1 and 3 (each within the scatter of the next); then compounds 2 and 4 (each within the scatter of the next).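

In this assay, exchanging the 1H-indol-4-yl group for 3-fluorophenyl gives a number 0.30 log units higher from compound 2 to compound 4 (within the scatter), so the two groups cannot be told apart on this read-out, even though the change removes a five-membered aromatic ring and the hydrogen-bond donor counted on the indole. The second aromatic group also stands far from the oxan-4-yl group of compound 1, with a number 1.70 log units higher from compound 1 to compound 4 (beyond the scatter), so the large step seen earlier is no longer tied to the indole alone but holds for both aromatic groups tested at this place. No separate measurement is available to explain what lies behind these numbers.

Going by these compounds, what the fluorine itself contributes stays open, since telling that apart would take a plain phenyl group at this place on the same core. Also open is how this assay would respond to a phenyl ring carrying an amine or a carboxylic acid, groups unlike any of those shown on this saturated chain carbon.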